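Swapping the Amine Chain on a Thiadiazole Amide Series

The compounds below may be only part of what the source reports. "The series", "measured", "known", "first", "only" and "open" are said of these compounds alone.

Compound 2, `COCCNc1nnc(SCC(=O)N(Cc2cccc([N+](=O)[O-])c2)c2ccc(F)cc2)s1`, carries a 2-methoxyethylamino group on its core. In an assay on isolated protein for inhibition of Amine oxidase [flavin-containing] A (Homo sapiens), read by fluorescence and Amplex Red, with a stated time of 30 min, tested at 0.01 nM (a higher number here means a stronger effect of the compound at the concentration tested, a lower number a weaker effect), compound 2 gives 13.5%, the highest of the two numbers recorded, while compound 1, `CCCCNc1nnc(SCC(=O)N(Cc2cccc([N+](=O)[O-])c2)c2ccc(F)cc2)s1`, gives 6.94%; the two values lie within the scatter of each other, as the step of a number 6.6 percentage points higher from compound 1 to compound 2 (within the scatter) shows. Compound 3, `CC(C)Nc1nnc(SCC(=O)N(Cc2cccc([N+](=O)[O-])c2)c2ccc(F)cc2)s1`, has not yet been measured. It differs from compound 2 by isopropyl in place of 2-methoxyethyl on a nitrogen on an aromatic ring. Within the data shown here, the only measured step that bears on this change is the one from compound 1 to compound 2, which altered the same chain on the same nitrogen and stayed within the scatter. Since that single comparison gave no movement beyond the scatter, he expects no step beyond the scatter here either, a number 3.5 percentage points lower from compound 2 to compound 3 (within the scatter). For compound 3 he therefore estimates 10% in this assay, with a range from 0% to 22%.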

Compound 3, a percentage reported as inhibition, at one concentration (the size of the read-out at that concentration, not a potency): 6.87%
Estimate against measurement, compound 3: 3.1 percentage points above; the measured number falls inside the stated range.
By their numbers in this assay, from the lowest: compounds 3, 1 and 2 (each within the scatter of the next).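

In this assay, isopropyl in place of 2-methoxyethyl on the nitrogen gives a number 6.6 percentage points lower from compound 2 to compound 3 (within the scatter) and isopropyl in place of butyl at the same place gives a number 0.1 percentage points lower from compound 1 to compound 3 (within the scatter) in the same reading. Among these compounds, the position has now taken three different chains, and no pair of them stands apart beyond the scatter. The hydrogen-bond acceptor of 2-methoxyethyl can leave, and the chain can change from butyl to isopropyl, without a step beyond the scatter. No measurement offered here accounts for these readings.

Going by these compounds, whether a larger change on this nitrogen, such as a chain ending in an amine or a carboxylic acid, or a phenyl ring, would move the number beyond the scatter stays open. So does whether these three chains would separate at another concentration.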